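A few compounds are considered here, and "the series" means these few. Any claim that something is new, unique, unknown or untested is made for them only; others in the source may bear on it.

Measured compounds in the series:

compound 1 `CC(C#Cc1cccc(C(=O)NCCC(c2ccccc2)c2ccc(OC(F)(F)F)cc2)c1)N(O)C(N)=O` — 110 nM
compound 2 `C[C@@H](C#Cc1cccc(C(=O)NCc2ccccc2C(F)(F)F)c1)N(O)C(N)=O` — 700 nM

In an assay for inhibition of Polyunsaturated fatty acid 5-lipoxygenase (Homo sapiens), read by HPLC, with stated times of 15 min and 10 min (a lower number here means a stronger inhibitor, a higher number a weaker inhibitor), compound 1 gives 110 nM, the lowest of the two numbers recorded. Compound 2 gives 700 nM, a gap from compound 1 that lies beyond the usual scatter; the two differ in several places at once, so the gap cannot be tied to any single change.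

Compound 3 `CC(C#Cc1cccc(C(=O)NCCC(c2ccccc2)c2ccc(F)cc2)c1)N(O)C(N)=O` differs from compound 1 in one place: fluoro in place of trifluoromethoxy on an aromatic carbon. Among the compounds with values here, no pair of measured compounds shows this change on its own, so there is no measured step to lean on.

The step from compound 1 to compound 3 is expected to be a 1.5-fold higher number from compound 1 to compound 3 (0.16 log units; within the scatter) in this assay, a small shift toward a higher number, likely within the scatter rather than beyond it. Compound 3 is accordingly estimated at 160 nM, with a range from 60 nM to 450 nM.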

Compound 3, half-maximal inhibitory concentration: 160 nM
Compound 3: the middle estimate sits on the measured number at the digits printed, within the range that was stated.
By their numbers in this assay, from the lowest: compounds 1 and 3 (each within the scatter of the next); then compound 2.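

In this assay, within the data shown here, the change from 4-(trifluoromethoxy)phenyl to 4-fluorophenyl gives a 1.5-fold higher number from compound 1 to compound 3 (0.16 log units; within the scatter), the first step that can be tied to a single place. On this aromatic carbon, para to a large group, trifluoromethoxy and fluoro therefore cannot be told apart in this assay, even though the group shrinks from five heavy atoms to one and its hydrogen-bond acceptor is gone. Nothing at hand accounts for this result.

On these data alone, whether the same carbon accepts a very different group, such as an amine or a carboxylic acid, remains open, as does the effect of plain hydrogen there. Two groups at one position also say nothing about how changes elsewhere in the shared core would read.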